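From fluoro to chloro on a shared core

The source may hold more compounds than are shown below. What is called first, only, known or untested is meant among the compounds shown, and "the series" means these compounds.

Compound 3 (`Fc1cc(Cl)cc2c(-c3ccc4ccccc4n3)c[nH]c12`) gives 0.633 h in an ADME assay on microsomes from liver (Homo sapiens) for metabolic stability, using NADPH, with a stated time of 40 min, tested at 2 uM (on this read-out higher numbers stand for a longer-lived compound and lower numbers for a shorter-lived compound), as its half-life. That lies within the scatter of compound 1 (`Fc1cc(Cl)c2[nH]cc(-c3ccc4ccccc4n3)c2c1`) at 0.383 h on the same read-out, and it stands clearly higher than compound 2 (`Clc1cccc2c(-c3ccc4ccccc4n3)c[nH]c12`) at 0.283 h on that read-out.

Compound 4 (`Clc1cc(Cl)c2[nH]cc(-c3ccc4ccccc4n3)c2c1`) departs from compound 3 in one place only. The change is chloro in place of fluoro on an aromatic carbon with chloro in place of fluoro on an aromatic carbon, on a six-membered aromatic ring of carbon only, ortho to a fused ring.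

Going by the values given here, no measured step makes this exact exchange. The nearest evidence is a 1.4-fold lower number from compound 1 to compound 2 (0.13 log units; within the scatter) where hydrogen takes the place of fluoro on an aromatic carbon, and that step stays within the scatter. It tells of a fluoro group leaving, but nothing direct about a chloro group entering. Compound 1 and compound 3, which carry the same two halogens, also sit within the scatter of each other.

On this thin basis, the expected move is a 1.3-fold lower number from compound 3 to compound 4 (0.10 log units; within the scatter) and no step beyond the scatter is foreseen. In this assay the estimate for compound 4 is 0.5 h with an expected range of 0.25 h to 1 h for this compound.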

Compound 4, half-life: 2.57 h
For compound 4 the middle estimate is 5.1-fold (0.71 log units) below the measured one, outside the stated range (above it).
By their numbers in this assay, from the lowest: compounds 2, 1 and 3 (each within the scatter of the next, the first and the last beyond it); then compound 4.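

In this assay, going by these compounds alone, chloro in place of fluoro on an aromatic carbon, ortho to a fused ring, gives a 4.1-fold higher number from compound 3 to compound 4 (0.61 log units; beyond the scatter), so this place responds to the halogen it carries in a way the earlier compounds gave no sign of. The same exchange at the other halogen-bearing aromatic carbon gives a 6.7-fold higher number from compound 1 to compound 4 (0.83 log units; beyond the scatter), and chloro in place of hydrogen at that carbon gives a 9.1-fold higher number from compound 2 to compound 4 (0.96 log units; beyond the scatter), whereas the only earlier step there, a 1.4-fold lower number from compound 1 to compound 2 (0.13 log units; within the scatter), stayed within the scatter; among these four compounds, then, the rise appears only when both halogens are chloro, with compound 4 above each of the other three by a margin beyond the scatter. No measurement given here accounts for this rise.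

The compounds shown leave open whether chloro itself matters at the place ortho to a fused ring or whether other groups there, such as bromo, methyl, methoxy or an amine, would give a similar half-life. They also leave open whether hydrogen at that place, with chloro kept at the other carbon, would sit nearer compound 3 or compound 4.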